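A few compounds are considered here, and "the series" means these few. Any claim that something is new, unique, unknown or untested is made for them only; others in the source may bear on it.

Measured so far:
- compound 1 `CN(C)c1ccc(C(=O)N2CCC(NS(=O)(=O)c3cc(S(=O)(=O)c4ccccc4)ccc3C(F)(F)F)CC2)cc1` — 300 nM in an assay on isolated protein for displacement of a labelled ligand from secreted frizzled-related protein 1 (Homo sapiens), read by fluorescence polarization, with a stated time of 30 min; on this read-out higher numbers stand for weaker inhibition and lower numbers for stronger inhibition
- compound 2 `O=C(c1ccccn1)N1CCC(NS(=O)(=O)c2cc(S(=O)(=O)c3ccccc3)ccc2C(F)(F)F)CC1` — 60 nM in this assay

Going by the values given here, compound 1 carries the higher of the two numbers in this assay; the only neighbour is compound 2, reached by a 5.0-fold lower number from compound 1 to compound 2 (0.70 log units; beyond the scatter), and that step changes the aryl that sits on the carbonyl carbon.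

Compound 3 `O=C(O)c1ccc(N2CCC(NS(=O)(=O)c3cc(S(=O)(=O)c4ccccc4)ccc3C(F)(F)F)CC2)cc1` departs from compound 1 in a different way: 4-carboxyphenyl in place of (4-(dimethylamino)phenyl)carbonyl on an amine nitrogen in a ring. The carbonyl itself leaves here, so the measured step bears on this change only loosely; it shows that the group on the ring nitrogen can shift the number by a modest amount. Among the compounds with values here, no measured pair shares the carboxyphenyl or the loss of the carbonyl.

Given that, compound 3 is expected to land near compound 1, as a 1.7-fold higher number from compound 1 to compound 3 (0.22 log units; within the scatter), with wide uncertainty in either direction. The estimate for compound 3 is 500 nM, expected to fall between 100 nM and 3000 nM.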

Compound 3, half-maximal inhibitory concentration: 120 nM
The estimate for compound 3 lay 4.2-fold (0.62 log units) above the measured number; the range from low to high includes it.
By their numbers in this assay, from the lowest: compounds 2 and 3 (each within the scatter of the next); then compound 1.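

In this assay, a carbonyl on the amine nitrogen of the shared core is not required for binding: replacing (4-(dimethylamino)phenyl)carbonyl with 4-carboxyphenyl gives a 2.5-fold lower number from compound 1 to compound 3 (0.40 log units; beyond the scatter) and keeps the aryl group on that nitrogen. Set against (pyridin-2-yl)carbonyl, the same group gives a 2.0-fold higher number from compound 2 to compound 3 (0.30 log units; within the scatter) and so leaves compound 2 and compound 3 unseparated, one with the carbonyl and one without. No supporting data on hand account for either step.

The compounds shown do not separate the carboxylic acid from the directly attached phenyl ring, a question that an unsubstituted phenyl, a methyl ester or a primary amide on that nitrogen would address. They also leave open how (4-carboxyphenyl)carbonyl, which carries both the acid and the carbonyl, would compare with compound 3 on this nitrogen.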